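The source may report more compounds than this note shows. Statements on the series, on what has been measured and on what is new or still open speak of the compounds shown alone.

In a functional assay on THP-1 cells (Homo sapiens) for inhibition, read by sulforhodamine B assay, with a stated time of 48 h, tested at 50 uM (on this read-out higher numbers stand for more inhibition of growth at the one concentration tested and lower numbers for less inhibition of growth), compound 1 (`COc1cccc(/C=C/C(=O)/C=C/c2ccc(OCc3cn(CCOc4cc(=O)oc5ccccc45)nn3)c(OC)c2)c1`) gives 77% and compound 2 (`COc1cc(/C=C/C(=O)/C=C/c2ccco2)ccc1OCc1cn(CCCCOc2cc(=O)oc3ccccc23)nn1`) gives 49% so compound 1 stands as the higher of the two, by a gap beyond the usual scatter. Compound 3 (`COc1cc(/C=C/C(=O)/C=C/c2ccccc2)ccc1OCc1cn(CCOc2cc(=O)oc3ccccc23)nn1`) departs from compound 1 in a single place: hydrogen in place of methoxy on an aromatic carbon with hydrogen in place of methoxy on an aromatic carbon, so that 3-methoxyphenyl becomes phenyl. Going by the values given here, no measured pair shows this change on its own, so the expectation rests only on compound 1 at 77% and on the modest size of the edit. The estimate puts a number 8 percentage points lower from compound 1 to compound 3 (within the scatter) in this assay as a small downward step, expected to stay within the scatter. Compound 3 is estimated at 69% with an expected range of 50% to 86% on this measure.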

Compound 3, percent growth inhibition at one concentration: 61%
Estimate against measurement, compound 3: 8 percentage points above, within the range that was stated.
By their numbers in this assay, from the lowest: compound 2; then compound 3; then compound 1.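

Going by these compounds alone, the step of a number 16 percentage points lower from compound 1 to compound 3 (beyond the scatter) in this assay gives the first comparison that isolates a single place, which compound 2 could not provide, as it differs from compound 1 in more than one place. It shows that this position, on an aromatic carbon meta to a large group, is not indifferent: going from 3-methoxyphenyl to phenyl costs a modest but real amount of growth inhibition, although compound 3 still gives 61%. Nothing available explains why the loss occurs.

The compounds shown leave open whether methoxy itself matters or whether other groups at this carbon, such as hydroxy, chlorine or an amine, would serve as well. They also leave open whether methoxy would give a similar step elsewhere on the same ring.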